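Does Losing the Sulfo Group Change Cell Tolerance?

The source may report more compounds than this note shows. Statements on the series, on what has been measured and on what is new or still open speak of the compounds shown alone.

Compound 1 `CCCCCCCCCCCCCC(=O)NC(CO[C@@H]1O[C@H](CO)[C@H](O)[C@H](O)[C@H]1O)C(=O)NCCOS(=O)(=O)O` gives > 100000 nM in a functional assay on MT4 cells (Homo sapiens) for cytotoxicity (a lower number here means that less compound is tolerated, a higher number that more compound is tolerated), and that value is a limit, not a number. Compound 2 `CCCCCCCCCCCCCCNC(=O)C(CO[C@@H]1O[C@H](CO)[C@H](O)[C@H](O)[C@H]1O)NC(=O)CCCCCCCCCCC(=O)O` has no sulfo group and gives > 100000 nM as a limit as well. The whole picture so far is the limit of > 100000 nM in this assay, at which 2 of the 2 values shown sit, and no size of any structural change can be read from it.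

Compound 3 `CCCCCCCCCCCCCC(=O)NC(CO[C@@H]1O[C@H](CO)[C@H](O)[C@H](O)[C@H]1O)C(=O)NCCO` differs from compound 1 in a single place. The change is hydrogen in place of sulfo on an oxygen on a saturated carbon with hydrogen in place of sulfo on an oxygen on a saturated carbon, so that 2-(sulfooxy)ethyl becomes 2-hydroxyethyl.

Among the compounds with values here, the only guide to this change is indirect. The expectation rests on compound 2 with its limit of > 100000 nM even without a sulfo group. The expected a number no higher from compound 1 to compound 3 (the limit leaves the size open) is therefore no change beyond the usual scatter in this assay and no clear direction. Compound 3 is estimated at 100000 nM with an expected range from 40000 nM to 200000 nM and the assay may well report only a limit again.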

Compound 3, half-maximal cytotoxic concentration: > 100000 nM
Compound 3 ended at the assay's limit; the forecaster's own chance of this, stated with the estimate: 75%; the middle value sits exactly at the limit.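

Compound 3 gives > 100000 nM in this assay and that value is again a limit. The step from compound 1 to compound 3 therefore cannot be read, and the whole set stays at one value: the limit of > 100000 nM in this assay, at which 3 of the 3 values shown sit. The compounds shown leave open what concentration harms these cells, and whether replacing sulfo with hydrogen changes it.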